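This account rests on a few compounds, and the source may have more. Where it says the series, first, only, none or still open, it means among the compounds named here.

The measured compounds and their values in a functional assay on A549 cells (Homo sapiens) for inhibition, read by MTT assay, with a stated time of 72 h; on this read-out higher numbers stand for weaker inhibition and lower numbers for stronger inhibition:
Compound 1 `COC(=O)c1ccc(-c2cn(CCCC(=O)Nc3ccc(C)cc3)nn2)cc1` gives only a limit of this assay, > 100000 nM.
Compound 2 `COC(=O)c1ccc(-c2cn(CCCC(=O)Nc3ccc(-c4ccccc4)cc3)nn2)cc1` gives 330 nM.
Compound 3 `COC(=O)c1ccc(-c2cn(CCCC(=S)Nc3ccc(C)cc3)nn2)cc1` gives 50000 nM.

Compound 1 and compound 2 share a core and differ in one place: phenyl in place of methyl on an aromatic carbon. This change gives an at least 300-fold lower number from compound 1 to compound 2 (2.48 log units; beyond the scatter), and the reading for compound 1 is a limit (the limit of > 100000 nM in this assay, at which 1 of the 3 values shown sits), so the full size of that step is not known. Compound 3 differs from compound 1 in another way; the difference between the two cores is not broken down here. Of the two measured numbers, compound 3 stands highest, and compound 2 lies far below it, beyond the scatter.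

Compound 4 `COC(=O)c1ccc(-c2cn(CCCC(=S)Nc3ccc(-c4ccccc4)cc3)nn2)cc1` has not been measured. It differs from compound 3 by phenyl in place of methyl on an aromatic carbon, the same change at the same place as that between compound 1 and compound 2. Resting on the step of an at least 300-fold lower number from compound 1 to compound 2 (2.48 log units; beyond the scatter), compound 4 is expected to show a step of a 63-fold lower number from compound 3 to compound 4 (1.80 log units; beyond the scatter), with the earlier step as its only guide. In this assay compound 4 is therefore estimated at 800 nM, between 150 nM and 8000 nM.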

Compound 4, half-maximal inhibitory concentration: 42300 nM
For compound 4 the middle estimate is 53-fold (1.72 log units) below the measured one; measured number above the stated range.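

In this assay, phenyl in place of methyl on an aromatic carbon gives a 1.2-fold lower number from compound 3 to compound 4 (0.07 log units; within the scatter), so on this core the two readings cannot be told apart. Set beside the earlier step, this shows that the change does not carry over with its size from the core of compound 1 to the core of compound 3: the same change on two cores in this assay, an at least 300-fold lower number (2.48 log units; beyond the scatter) from compound 1 to compound 2 and a 1.2-fold lower number (0.07 log units; within the scatter) from compound 3 to compound 4, at least 250-fold (2.40 log units) apart, beyond the scatter of two such steps. From the compounds shown here alone, the reading of compound 1 is only a limit, so the full size of the earlier step stays unknown, and two pairs show neither why the steps part nor how the change would read on any further core: the limit of > 100000 nM in this assay, at which 1 of the 4 values shown sits.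

The compounds shown leave open how other groups at the same place, such as ethyl, methoxy or pyridyl, would read on either core. They also leave open whether a carboxylic acid in place of the methyl ester, or a longer chain before the carbonyl or its sulfur counterpart, would alter the gap between the two steps.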